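Swapping an imidazole for bromine on a chalcone

This account rests on a few compounds, and the source may have more. Where it says the series, first, only, none or still open, it means among the compounds named here.

Compound 1 `COc1cc(OC)c(-c2cc(=O)c3cc(O)ccc3o2)cc1OC`: > 150000 nM
Compound 2 `COc1cc(OC)c(OC)cc1/C=C/C(=O)c1ccc(-c2c[nH]cn2)cc1`: > 150000 nM

These two compounds were tested in a functional assay on HeLa cells (Homo sapiens) for inhibition, read by MTT assay, with a stated time of 72 h; a lower number here means a stronger inhibitor, a higher number a weaker inhibitor. For compound 1 the reported value is a limit of the assay, not a measured number. From the compounds shown here alone, for compound 2 the reported value is likewise a limit, so its true potency is unknown beyond being weak. Both values sit at the limit of > 150000 nM in this assay, at which 2 of the 2 values shown sit.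

Compound 3 `COc1cc(OC)c(OC)cc1/C=C/C(=O)c1ccc(Br)cc1` has not yet been tested in this assay. It differs from compound 2 in one place: bromo in place of 1H-imidazol-4-yl on an aromatic carbon. Among the compounds with values here, no measured step between two compounds is available here, so the size of this change cannot be read from the data. Since compound 2 gave only a limit, compound 3 is expected to remain weak as well, with an estimated step of an at least 1.5-fold lower number from compound 2 to compound 3 (0.17 log units; that floor lies within the scatter) meaning little beyond the scatter. Compound 3 is expected to give about 100000 nM, in a range of 20000 nM to 300000 nM.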

Compound 3, half-maximal inhibitory concentration: 31700 nM
Estimate against measurement, compound 3: 3.2-fold (0.50 log units) above, within the range that was stated.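

In this assay, placing bromo instead of 1H-imidazol-4-yl on this aromatic carbon, para to a large group, gives an at least 4.7-fold lower number from compound 2 to compound 3 (0.67 log units; beyond the scatter). This shows that the position can affect the read-out, and that the group entering here, with no ring and no hydrogen-bond donor, yields a measured value rather than a limit. The true size of the step remains unknown because compound 2 sits at a limit of the assay, not at a measured number: the limit of > 150000 nM in this assay, at which 2 of the 3 values shown sit.

The compounds shown leave open whether bromine itself matters or whether losing the imidazole ring is enough. A plain hydrogen, a chlorine or a methoxy group at this position could help separate these two readings, and an amine or a carboxylic acid would test quite different groups there.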